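From hydroxy to iodo: one swap, one expected shift

A few compounds are considered here, and "the series" means these few. Any claim that something is new, unique, unknown or untested is made for them only; others in the source may bear on it.

compound 1 `O=C(CCCCCCC(=O)Nc1ccc(O)cc1)NO` gives 6400 nM
compound 2 `O=C(CCCCCCC(=O)Nc1cccc(C(F)(F)F)c1)NO` gives 1200 nM

Both numbers come from a functional assay on U-937 cells (Homo sapiens) for antiproliferative activity, with a stated time of 48 h (a higher number here means that more compound is needed for the effect, a lower number that less compound is needed), and compound 1 has the higher of the two, so it needs more compound for the effect. The gap down to compound 2 lies beyond the usual scatter.

Compound 3 `O=C(CCCCCCC(=O)Nc1ccc(I)cc1)NO` has not yet been measured. It differs from compound 1 in one place, with iodo in place of hydroxy on an aromatic carbon, para to a large group (iodo in place of hydroxy on an aromatic carbon).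

For the measured compounds named here, no measured pair shows this swap directly, so the only guide is a loose one. Compound 2 also lacks the hydroxy group and gives 1200 nM in this assay but it differs from compound 1 in more than that. A lower number is therefore expected for the swap, though with real uncertainty. The expected move, a 4.3-fold lower number from compound 1 to compound 3 (0.63 log units; beyond the scatter) and so downward, would lie beyond the scatter. The estimated value for compound 3 is 1500 nM with an expected range running from 500 nM to 4500 nM at its upper end, and the measurement will test this.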

Compound 3, half-maximal effective concentration: 120 nM
Estimate against measurement, compound 3: 13-fold (1.10 log units) above; the whole stated range lies above it.
By their numbers in this assay, from the lowest: compound 3; then compound 2; then compound 1.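

In this assay, iodo in place of hydroxy now has a direct reading: the swap gives a 53-fold lower number from compound 1 to compound 3 (1.73 log units; beyond the scatter), a large step that shows this place on the ring, para to a large group, is far from indifferent to what sits there. By count the change is small, as one heavy atom leaves and one enters, no ring and no net charge are involved, and only the hydrogen-bond donor and acceptor of the hydroxy group disappear without replacement, so a single-atom exchange on the aromatic carbon is enough to move the number well beyond the scatter. Nothing available explains why the step is so large, since no outside measurement bears on either group at this place.

Going by these compounds, a single pair cannot separate what iodo adds from what the loss of hydroxy removes, so it remains open how a plain hydrogen, a chloro group, a methoxy group or an amine at the same place would compare with compound 1 and compound 3. On these data alone, it also remains open whether the step would keep its size on a compound with a longer chain.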